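Swapping the anilide ring back toward a halogenated pattern

The source may hold more compounds than are shown below. What is called first, only, known or untested is meant among the compounds shown, and "the series" means these compounds.

compound 1 `COc1ccc2nc(C)cc(OCC(=O)Nc3ccc(Br)c(C)c3)c2c1` — < 1000 nM
compound 2 `COc1ccc2nc(C)cc(OCC(=O)Nc3cc(F)cc(F)c3)c2c1` — 13000 nM

The two measured compounds share one core and differ only in the ring attached to the amide-type nitrogen. In a physicochemical assay for solubility, in phosphate buffer, measured as kinetic solubility, with a stated time of 1 h, at pH 7.4 (a lower number here means a less soluble compound, a higher number a more soluble compound), compound 2 gives 13000 nM. For compound 1 this assay reports only a limit, < 1000 nM, so no number is known for it. Among the measured compounds shown here, the single measured step is an at least 13-fold higher number from compound 1 to compound 2 (1.11 log units; beyond the scatter). Compound 2 therefore holds the only real number shown; the other entry is the limit of < 1000 nM in this assay, at which 1 of the 2 values shown sits.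

Compound 3 `COc1ccc2nc(C)cc(OCC(=O)Nc3ccc(Cl)c(OC)c3)c2c1` has not been measured. Its change from compound 2 is 4-chloro-3-methoxyphenyl in place of 3,5-difluorophenyl on an amide-type nitrogen. This largely reverses the measured step: a ring bearing a halogen together with a second small group comes back, as in compound 1, while the two fluorines leave. That step from compound 1 to compound 2 is the only one that bears on this change, and it was large; run backwards, it points to a sizeable drop for compound 3, though the limit at compound 1 leaves the exact size open. The expected step is an 8.7-fold lower number from compound 2 to compound 3 (0.94 log units; beyond the scatter) in this assay. Compound 3 is estimated at 1500 nM, with a range from 400 nM to 6000 nM, and it may again land at the limit.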

Compound 3, solubility: 13000 nM
Estimate against measurement, compound 3: 8.7-fold (0.94 log units) below, outside the stated range (above it).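

In this assay, replacing 3,5-difluorophenyl with 4-chloro-3-methoxyphenyl on the amide-type nitrogen gives no change at the digits printed from compound 2 to compound 3 (within the scatter), so these two quite differently substituted rings cannot be told apart in this measurement. A ring carrying a halogen and a second group therefore does not by itself bring a low reading, since 4-bromo-3-methylphenyl and 4-chloro-3-methoxyphenyl both fit that description and yet the change between them gives an at least 13-fold higher number from compound 1 to compound 3 (1.11 log units; beyond the scatter). The entry for compound 1 is a limit and not a number: the limit of < 1000 nM in this assay, at which 1 of the 3 values shown sits.

Among the compounds shown here, what remains open is which difference between compound 1 and compound 3 carries that step, as bromine and chlorine differ along with methyl and methoxy, and these compounds offer no ring in which only one of the two pairs changes. Also open is how the reading would respond to an amine or a carboxylic acid on this ring, since every ring shown carries only halogens, methyl or methoxy.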